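The compounds below may be only part of what the source reports. "The series", "measured", "known", "first", "only" and "open" are said of these compounds alone.

Of the compounds shown here, three have been tested in a functional assay on ileum for antagonist activity at muscarinic acetylcholine receptor M3 (Cavia porcellus) (on this read-out higher numbers stand for weaker inhibition and lower numbers for stronger inhibition), with a fourth awaiting the same measurement. Among the measured compounds shown here, compound 2 `O=C(CN1CCN(Cc2cccs2)CC1)C(O)(c1ccccc1)C1CCC1` gives 43.8 nM, the only definite number among them. Compound 1 `O=C(CN1CCC(N2CCCC2)CC1)C(O)(c1ccccc1)C1CCC1` reaches only the assay limit of > 10000 nM. Compound 3 `CCOC(=O)N1CCN(CC(=O)C(O)(c2ccccc2)C2CCCCC2)CC1` likewise stops at the limit of > 10000 nM. Compound 4 `CC(C)=CCN1CCN(CC(=O)C(O)(c2ccccc2)C2CCC2)CC1` differs from compound 2 by one change: 2-methylprop-1-en-1-yl in place of thiophen-2-yl on a saturated chain carbon bound to an amine nitrogen in a ring. For the measured compounds named here, no step between two measured compounds is available to judge such a swap, so the expectation rests on compound 2 alone. The exchange of one small group for another at the ring nitrogen is expected to move potency only modestly, toward weaker inhibition, as a step of a 2.7-fold higher number from compound 2 to compound 4 (0.44 log units; beyond the scatter). Compound 4 is therefore estimated at 120 nM, within the range 25 nM to 700 nM.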

Compound 4, antagonist equilibrium constant: 22 nM
Estimate against measurement, compound 4: 5.5-fold (0.74 log units) above; measured number outside the range, below it.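

In this assay, among the compounds shown here, the change gives a 2.0-fold lower number from compound 2 to compound 4 (0.30 log units; within the scatter), the first direct reading at this position. On a saturated chain carbon bound to an amine nitrogen in a ring, an open chain with one double bond can therefore stand in place of the sulfur-containing aromatic ring with no change beyond the scatter. Nothing measured here explains why the two groups read alike.

On these data alone, whether a phenyl ring, a longer saturated chain, an amine or a carboxylic acid would be tolerated at this place remains open. This single pair also cannot show whether the change would read the same on another core.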